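This account rests on a few compounds, and the source may have more. Where it says the series, first, only, none or still open, it means among the compounds named here.

Measured in an ADME assay on microsomes from liver (Homo sapiens) for metabolic stability, read by LC-MS, using NADPH, with a stated time of 10 min, tested at 10 uM; on this read-out higher numbers stand for a longer-lived compound and lower numbers for a shorter-lived compound:
- Compound 1 `N#Cc1ccnc(Oc2nn(C3CCC3)c3ncnc(N)c23)c1`: 2.35 h
- Compound 2 `Nc1ncnc2c1c(Oc1cc(C(F)(F)F)ccn1)nn2[C@H]1CC[C@H](CO)CC1`: > 2.41 h

Compound 2 stands at the limit of > 2.41 h in this assay, at which 1 of the 2 values shown sits, and this value is a limit and not a number.

The next compound is compound 3 `Nc1ncnc2c1c(Oc1cc(C(F)(F)F)ccn1)nn2C1CCC1`, with cyclobutyl in place of 4-(hydroxymethyl)cyclohexyl on an aromatic nitrogen. For the measured compounds named here, no measured pair in this assay isolates this change, so the expectation rests on a single reference. Compound 1 also carries cyclobutyl on that nitrogen and gives 2.35 h, so no step beyond the usual scatter is expected, in either direction. The expected change is an at least 1.0-fold lower number from compound 2 to compound 3 (0.03 log units; that floor lies within the scatter). For compound 3 the estimated half-life is 2.2 h, with an expected range of 1.2 h to 3 h. A report of a limit in place of a number remains quite possible.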

Compound 3, half-life: 1.02 h
Estimate against measurement, compound 3: 2.2-fold (0.33 log units) above; the measured number lies below the stated range.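

In this assay, the group on the aromatic nitrogen counts in this series: with trifluoromethyl held fixed, cyclobutyl in place of 4-(hydroxymethyl)cyclohexyl gives an at least 2.3-fold lower number from compound 2 to compound 3 (0.37 log units; beyond the scatter). Compound 2 stands at a limit and not a number, so that step has a floor only: the limit of > 2.41 h in this assay, at which 1 of the 3 values shown sits.

With cyclobutyl held fixed, the aromatic carbon counts as well: trifluoromethyl in place of cyano gives a 2.3-fold lower number from compound 1 to compound 3 (0.36 log units; beyond the scatter), so a half-life read with cyano does not carry over to the trifluoromethyl analogue.

The compounds shown do not separate the six-membered ring of 4-(hydroxymethyl)cyclohexyl from its hydroxymethyl, and a plain cyclohexyl on that nitrogen would bear on this. Also open, from the compounds shown here alone, are the full size of the step from the limit and how cyano behaves alongside the larger group.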